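Thian-4-yl in Place of Cyclohexylmethyl on an Amine

A few compounds are considered here, and "the series" means these few. Any claim that something is new, unique, unknown or untested is made for them only; others in the source may bear on it.

Measured compounds:
Compound 1, `c1ccc(CN(CCCCN(C[C@H]2Cc3ccccc3CN2)[C@H]2CCCc3cccnc32)Cc2ccccn2)nc1`, gives > 30000 nM, a limit.
Compound 2, `c1ccc2c(c1)CN[C@@H](CN(CCCCNCC1CCCCC1)[C@H]1CCCc3cccnc31)C2`, gives > 30000 nM, a limit.

Both compounds were tested in a functional assay on cells for agonist activity at C-X-C chemokine receptor type 4 (Homo sapiens), read by fluorescence and calcium flux, with a stated time of 90 s; a lower number here means that less compound is needed, a higher number that more compound is needed for the effect. For compound 2 the readout is a limit, not a number. Compound 1 likewise ends at a limit. Going by the values given here, compound 2 therefore stands where every value shown stands: at the limit of > 30000 nM in this assay, at which 2 of the 2 values shown sit, and no measured step separates it from another compound.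

Compound 3, `c1ccc2c(c1)CN[C@@H](CN(CCCCNC1CCSCC1)[C@H]1CCCc3cccnc31)C2`, is not yet measured. It differs from compound 2 in one place: thian-4-yl in place of cyclohexylmethyl on an amine nitrogen. The rest of the molecule, including the shared core, is unchanged.

Among the compounds with values here, with no measured step between compounds to draw on, and with compound 2 resting at a limit, the expectation for compound 3 is that the change from cyclohexylmethyl to thian-4-yl produces no step beyond the scatter, and the assay most likely again reports a limit. The expected step of a number no higher from compound 2 to compound 3 (the limit leaves the size open) is thus essentially none. Compound 3 is expected to give about 30000 nM in this assay, with a range from 10000 nM to 100000 nM.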

Compound 3, half-maximal effective concentration: > 30000 nM
Compound 3 was reported as a limit; the forecaster's own chance of this, stated with the estimate: 85%; the middle value lies on the limit itself.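

In this assay compound 3 gives > 30000 nM, which is a limit and not a number. Going by these compounds alone, compound 2 also ends at a limit, so no step from compound 2 to compound 3 can be read for thian-4-yl in place of cyclohexylmethyl. The compounds shown leave open whether this change affects the concentration needed at all.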